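Chloro for fluoro on the shared core

A few compounds are considered here, and "the series" means these few. Any claim that something is new, unique, unknown or untested is made for them only; others in the source may bear on it.

In an ADME assay on microsomes from liver (Mus musculus) for metabolic stability (a higher number here means faster removal of the compound, a lower number slower removal), compound 1 `O=C(Nc1ccc(Cl)cc1)C(=O)N1CCC(c2ccnc3ccc(F)cc23)CC1` gives 97 mL.min-1.g-1. Compound 3 `O=C(Nc1ccc(Cl)cn1)C(=O)N1CCC(c2ccnc3ccc(F)cc23)CC1` gives 112 mL.min-1.g-1, within the scatter of compound 1, whereas compound 2 `O=C(Nc1ccc(C(F)(F)F)cc1)C(=O)N1CCC(c2ccnc3ccc(F)cc23)CC1` gives 16 mL.min-1.g-1. Compound 1 therefore sits in the upper group of this small set, clearly separated only from compound 2.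

Compound 4 `O=C(Nc1ccc(Cl)cc1)C(=O)N1CCC(c2ccnc3ccc(Cl)cc23)CC1` differs from compound 1 on the core: chloro in place of fluoro on an aromatic carbon. Among the measured compounds shown here, no measured step changes that place. The nearest in kind is a 6.1-fold lower number from compound 1 to compound 2 (0.78 log units; beyond the scatter), where trifluoromethyl replaces chloro on an aromatic carbon of another ring. It shows that a single substituent swap can move this number, but it is a different group at a different place. The heteroaryl swap, a 1.2-fold higher number from compound 1 to compound 3 (0.06 log units; within the scatter), left the number within the scatter. Neither step gives a direction for the core change, so the expected step is a 1.1-fold higher number from compound 1 to compound 4 (0.05 log units; within the scatter), with nothing expected beyond the scatter. For compound 4 the estimated value is 110 mL.min-1.g-1, with an expected range of 55 mL.min-1.g-1 to 220 mL.min-1.g-1.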

Compound 4, intrinsic clearance in microsomes: 72 mL.min-1.g-1
Compound 4: middle estimate off by 1.5-fold (0.18 log units), on the high side; the range from low to high includes it.
By their numbers in this assay, from the lowest: compound 2; then compounds 4, 1 and 3 (each within the scatter of the next).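

In this assay, this core position now has a measured step of its own: a 1.3-fold lower number from compound 1 to compound 4 (0.13 log units; within the scatter) for chloro in place of fluoro on an aromatic carbon. Among the compounds shown here, this step within the scatter stands with the heteroaryl swap, a 1.2-fold higher number from compound 1 to compound 3 (0.06 log units; within the scatter), while a 6.1-fold lower number from compound 1 to compound 2 (0.78 log units; beyond the scatter) remains the only step from compound 1 beyond the scatter. No measurement shown here explains any of these numbers.

Still open, as far as these compounds go, is how a nitrile, a methoxy group or an amine at this place on the core would read in this assay. Also open, from the compounds shown here alone, is whether trifluoromethyl in place of chloro on the other ring would give a similar step with chloro on the core, as in compound 4.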